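Aryl ketone variation on a trimethoxyphenyl pyrazole chalcone

The compounds below may be only part of what the source reports. "The series", "measured", "known", "first", "only" and "open" are said of these compounds alone.

Measured compounds in the series:
- compound 1 `COc1cc(-c2cc(/C=C/C(=O)c3ccc(N)cc3)[nH]n2)cc(OC)c1OC` gives 3750 nM in a functional assay on OVCAR-5 cells (Homo sapiens) for inhibition, read by sulforhodamine B assay, with a stated time of 48 h; a higher number here means a weaker inhibitor of growth, a lower number a stronger inhibitor of growth
- compound 2 `COc1ccc(C(=O)/C=C/c2cc(-c3cc(OC)c(OC)c(OC)c3)n[nH]2)cc1OC` gives 3030 nM in this assay
- compound 3 `COc1ccc(C(=O)/C=C/c2cc(-c3cc(OC)c(OC)c(OC)c3)n[nH]2)cc1` gives 3780 nM in this assay

All three compounds share the same core and differ only in the aryl group on the carbonyl carbon. Compound 3 carries the highest of the three numbers in this assay, but its gaps to compound 1 and to compound 2 are both within the scatter, so no order among the three can be drawn.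

Compound 4 `COc1cc(-c2cc(/C=C/C(=O)c3ccc(F)c(F)c3)[nH]n2)cc(OC)c1OC` has not been measured. It differs from compound 3 by 3,4-difluorophenyl in place of 4-methoxyphenyl on a carbonyl carbon.

Three measured steps change the same aryl group on the carbonyl carbon: a 1.2-fold lower number from compound 1 to compound 2 (0.09 log units; within the scatter), a 1.0-fold higher number from compound 1 to compound 3 (0.00 log units; within the scatter) and a 1.2-fold higher number from compound 2 to compound 3 (0.10 log units; within the scatter). Each is within the scatter, so swapping amino, methoxy or hydrogen on that ring left the readout essentially unchanged. None of these steps involves fluorine, so the difluoro substitution is not directly covered, but the absence of any movement across the three prior variations gives no ground to expect a step beyond the scatter in this assay in either direction.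

Compound 4 is therefore estimated at 3500 nM in this assay, with a range of 1400 nM to 9000 nM. The expected step from compound 3 is a 1.1-fold lower number from compound 3 to compound 4 (0.03 log units; within the scatter).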

Compound 4, concentration for total growth inhibition: 33800 nM
Compound 4: middle estimate off by 9.7-fold (0.98 log units), on the low side, outside the stated range (above it).
By their numbers in this assay, from the lowest: compounds 2, 1 and 3 (each within the scatter of the next); then compound 4.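

The aryl group on the carbonyl carbon is not a silent position: in this assay placing 3,4-difluorophenyl there gives an 8.9-fold higher number from compound 3 to compound 4 (0.95 log units; beyond the scatter) as well as an 11-fold higher number from compound 2 to compound 4 (1.05 log units; beyond the scatter) and a 9.0-fold higher number from compound 1 to compound 4 (0.95 log units; beyond the scatter) so the flat readout among compound 1, compound 2 and compound 3 held only for those three groups. Growth inhibition in this series therefore does depend on this aryl group, with compound 4 the weakest of the four, since its steps to all the others lie beyond the scatter. The 4-methoxyphenyl that leaves and the 3,4-difluorophenyl that enters both hold 8 heavy atoms, so that count does not separate them, while the hydrogen-bond acceptors go from 1 to 0, and no measurement in hand explains the step.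

Still open, going by these compounds, is whether the higher number needs both fluorines, which a single fluoro group, a chloro group or a trifluoromethyl group on this ring would help to settle. Also open, on these data alone, is where an unsubstituted phenyl on the carbonyl carbon would fall relative to compound 3 and compound 4.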